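Does a longer amine chain change tolerance?

A few compounds are considered here, and "the series" means these few. Any claim that something is new, unique, unknown or untested is made for them only; others in the source may bear on it.

Measured in an ADME assay on HOS cells (Homo sapiens) for cytotoxicity (a lower number here means that less compound is tolerated, a higher number that more compound is tolerated), each value a limit of the assay:
- compound 1 `CN(Cc1nc2ccccc2n1CCCNC(=N)N)C1CCCc2cccnc21`: > 20000 nM
- compound 2 `CN(Cc1nc2cccc(C(=O)NCCCN)c2[nH]1)C1CCCc2cccnc21`: > 20000 nM
- compound 3 `CN(Cc1nc2cccc(CN)c2[nH]1)C1CCCc2cccnc21`: > 20000 nM

In this assay compound 3 gives > 20000 nM, which is a limit of the assay and not a number. It therefore has no exact place among the measured compounds, and the record shows only (the limit of > 20000 nM in this assay, at which 3 of the 3 values shown sit).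

The next compound is compound 4 `CN(Cc1nc2cccc(CCCN3CCCC3)c2[nH]1)C1CCCc2cccnc21`. Its change from compound 3 is 2-(pyrrolidin-1-yl)ethyl in place of amino on a saturated chain carbon bound to an aromatic carbon. In words, 2-(pyrrolidin-1-yl)ethyl replaces amino on a saturated chain carbon bound to an aromatic carbon, so aminomethyl becomes 3-(pyrrolidin-1-yl)propyl.

Among the measured compounds shown here, only one measured step bears on this change, and it also swaps one amine-bearing group for another: a step that the two limits leave unreadable from compound 2 to compound 3. It offers no size to carry over. Going by a step that the two limits leave unreadable from compound 2 to compound 3, no step beyond the scatter is expected in this assay, in either direction. The expected change is a number no higher from compound 3 to compound 4 (the limit leaves the size open). A further limit is the most likely report for this compound, although a measurable number cannot be ruled out. For compound 4 the estimated value is 20000 nM, with an expected range from 10000 nM to 30000 nM.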

Compound 4, half-maximal cytotoxic concentration: 8200 nM
The estimate for compound 4 lay 2.4-fold (0.39 log units) above the measured number; the whole stated range lies above it.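

In this assay, this position on the shared core now gives its first readable change: putting 3-(pyrrolidin-1-yl)propyl in place of aminomethyl on an aromatic carbon produces an at least 2.4-fold lower number from compound 3 to compound 4 (0.38 log units; beyond the scatter). Putting the same group in place of (3-aminopropyl)carbamoyl on an aromatic carbon produces an at least 2.4-fold lower number from compound 2 to compound 4 (0.38 log units; beyond the scatter), so among these three compounds, tolerance falls only with the 3-(pyrrolidin-1-yl)propyl group. The true size of both steps stays open because each starts from a compound reported only as a limit, not as a number: the limit of > 20000 nM in this assay, at which 3 of the 4 values shown sit.

The step between compound 2 and compound 3 cannot be read, which leaves unanswered whether changing between those two amine-bearing groups has any effect on tolerance. Compound 4 also differs from compound 3 in both the length of the chain and the pyrrolidine at its end, so the cause of the lower number remains unresolved, and a plain 3-aminopropyl group or a pyrrolidin-1-ylmethyl group at this position would help separate those two changes.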